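Swapping a Ring for a Branched Chain

The source may report more compounds than this note shows. Statements on the series, on what has been measured and on what is new or still open speak of the compounds shown alone.

Compound 1, `O=C(O)CCNC(=O)c1ccc(C(Oc2ccc(-n3cc(C(F)(F)F)cn3)cc2)C2CCCC2)cc1`, carries a cyclopentyl group on the saturated carbon that links its two aromatic parts. In an ADME assay on microsomes from liver (Homo sapiens) for metabolic stability (on this read-out higher numbers stand for fast clearance and lower numbers for slow clearance), compound 1 gives 22 mL/min/kg. Within the data shown here, the only other measured compound is compound 2, `CCCC(Oc1ccc(-n2cc(F)cn2)cc1)c1ccc(C(=O)NCCC(=O)O)cc1`, which differs from compound 1 in more than one place, so no single change can be read from the pair. In this assay compound 2 gives 12 mL/min/kg. Of the two numbers, that of compound 1 is the larger, but the gap to compound 2 lies within the usual scatter, so the two cannot be told apart.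

Compound 3, `CC(C)CC(Oc1ccc(-n2cc(C(F)(F)F)cn2)cc1)c1ccc(C(=O)NCCC(=O)O)cc1`, differs from compound 1 by isobutyl in place of cyclopentyl on a saturated chain carbon bound to an aromatic carbon and an oxygen on an aromatic ring. The shared core, the amide and the acid chain remain unchanged. Among the measured compounds shown here, no measured pair shows a change of this kind, so there is no step to lean on. With nothing in the data pointing either way, the step from compound 1 to compound 3 is expected to stay within the scatter, a 1.1-fold lower number from compound 1 to compound 3 (0.04 log units; within the scatter). Compound 3 is therefore estimated at 20 mL/min/kg, with a range from 10 mL/min/kg to 40 mL/min/kg.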

Compound 3, clearance: 23 mL/min/kg
Compound 3: the middle estimate sits 1.2-fold (0.06 log units) below what was measured; measured number inside the range.
By their numbers in this assay, from the lowest: compounds 2, 1 and 3 (each within the scatter of the next).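

Among these compounds, compound 1 and compound 3 differ in one place only, so this pair gives the first reading of a single change: isobutyl in place of cyclopentyl on a saturated chain carbon bound to an aromatic carbon and an oxygen on an aromatic ring. In this assay, the step is a 1.0-fold higher number from compound 1 to compound 3 (0.02 log units; within the scatter), so the two compounds cannot be told apart, even though the five-membered ring of carbon only is gone and the group has 4 heavy atoms instead of 5. Nothing available speaks to what lies behind this result.

On these data alone, both groups in this pair are built from carbon alone, so it remains open whether the same reading would hold for a group containing an amine or a carboxylic acid, or for a longer chain or a phenyl ring at this position. Compound 2 carries a different group at this carbon and also differs elsewhere, so the pairs it forms with compound 1 and compound 3 cannot separate the contribution of either change.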